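This account rests on a few compounds, and the source may have more. Where it says the series, first, only, none or still open, it means among the compounds named here.

In a functional assay on MCF7 cells (Homo sapiens) for inhibition, read by MTT assay, with a stated time of 72 h (on this read-out lower numbers stand for stronger inhibition and higher numbers for weaker inhibition), compound 3 `Nc1nc2cc(-c3nn(CCC(=O)NO)c4ncnc(N)c34)ccc2o1` stands at > 100000 nM as a limit and not a number. Compound 1 `Nc1ncnc2c1c(-c1cnc3[nH]ccc3c1)nn2CCCCCC(=O)NO` gives > 150000 nM as a limit too. Compound 2 `Nc1nc2cc(-c3nn(CCCCCCCCCC(=O)NO)c4ncnc(N)c34)ccc2o1` gives > 50000 nM as a limit as well. Within the data shown here, no compound here has a readable value yet.

Compound 4 `Nc1nc2cc(-c3nn(CCCCCCCCC(=O)NO)c4ncnc(N)c34)ccc2o1` differs from compound 3 by one change (6-(hydroxycarbamoyl)hexyl in place of hydroxycarbamoyl on a saturated chain carbon, two bonds along the chain from an aromatic nitrogen): 6-(hydroxycarbamoyl)hexyl in place of hydroxycarbamoyl on a saturated chain carbon, two bonds along the chain from an aromatic nitrogen. Among the measured compounds shown here, the only measured step that bears on it is a step that the two limits leave unreadable from compound 2 to compound 3 and it offers no size to carry over.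

The expectation therefore rests on compound 2, at > 50000 nM as a limit, and on the absence of any readable value in the series. No shift beyond the usual scatter is expected in either direction: the estimated change is an at least 1.6-fold lower number from compound 3 to compound 4 (0.22 log units; that floor lies within the scatter) and another limit is the likeliest report. In this assay compound 4 is estimated at 60000 nM with an expected range of 15000 nM to 150000 nM as the working figure.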

Compound 4, half-maximal inhibitory concentration: 42100 nM
Estimate against measurement, compound 4: 1.4-fold (0.15 log units) above, and the stated range covers the measured number.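

Among these compounds, the first readable value in this assay comes with 6-(hydroxycarbamoyl)hexyl in place of hydroxycarbamoyl on a saturated chain carbon, two bonds along the chain from an aromatic nitrogen: an at least 2.3-fold lower number from compound 3 to compound 4 (0.37 log units; beyond the scatter). This size is only a floor because one end of the step is a limit and not a number: the limit of > 100000 nM in this assay, at which 1 of the 4 values shown sits.

Hydroxycarbamoyl in place of (hydroxycarbamoyl)methyl on a saturated chain carbon, eight bonds along the chain from an aromatic nitrogen, gives an at least 1.1-fold lower number from compound 2 to compound 4 (0.07 log units; that floor lies within the scatter), so no order can be set between these two chain lengths.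

The step between the two limit compounds cannot be read. On these data alone, whether a carboxylic acid in place of the hydroxycarbamoyl group, or a chain shorter than 6-(hydroxycarbamoyl)hexyl, would give a readable value stays open.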